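Ethyl in Place of Trifluoromethyl: Estimating Compound 3

The source may report more compounds than this note shows. Statements on the series, on what has been measured and on what is new or still open speak of the compounds shown alone.

Measured so far:
Compound 1, `Brc1ccc2ccn(CCN3CCN4CCCCC4C3)c2c1`: 70 nM
Compound 2, `CN1CCCN(CCn2ccc3ccc(C(F)(F)F)cc32)CC1`: 23 nM

In an assay on HEK293 cells for binding affinity to 5-hydroxytryptamine receptor 7 (Homo sapiens), read by radioligand binding (on this read-out lower numbers stand for stronger inhibition and higher numbers for weaker inhibition), compound 2 gives 23 nM, the lower of the two numbers measured. Compound 1 gives 70 nM, and the gap between the two lies beyond the usual scatter of repeated measurements, so compound 2 stands as the stronger binder of this small pair. For the measured compounds named here, the two compounds differ in more than one place, so no single measured step connects them.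

Compound 3, `CCc1ccc2ccn(CCN3CCCN(C)CC3)c2c1`, differs from compound 2 in one place: ethyl in place of trifluoromethyl on an aromatic carbon. Going by the values given here, no measured pair shows what this exchange does, so the expected step rests on the structural change alone. A modest step is expected in this assay, more likely toward a weaker number than a stronger one, and possibly none beyond the scatter. For compound 3 the estimated result in this assay is 40 nM, within a range from 12 nM to 130 nM, which means an expected step of a 1.7-fold higher number from compound 2 to compound 3 (0.24 log units; within the scatter).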

Compound 3, inhibition constant: 166 nM
The estimate for compound 3 lay 4.2-fold (0.62 log units) below the measured number, and the stated range ends below it.
By their numbers in this assay, from the lowest: compound 2; then compound 1; then compound 3.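

In this assay, ethyl in place of trifluoromethyl on this aromatic carbon gives a 7.2-fold higher number from compound 2 to compound 3 (0.86 log units; beyond the scatter). This is the first single-place comparison among the compounds shown, and it establishes that the group at this position affects the number: of the two groups, trifluoromethyl goes with the stronger binding on this core, and ethyl does not serve as an equivalent replacement. Both groups have no ring, no hydrogen-bond donors or acceptors and no net charge, so those counts do not separate them, and nothing measured here explains the size of the step.

For the compounds shown here, with only two groups compared at this position in a single pair, it remains open where others would fall, such as a methyl, a methoxy, a nitrile or a single chlorine atom, and whether any would match or improve on trifluoromethyl. It is also open whether the same exchange would give a similar step with the side chain of compound 1, since no pair shown tests it there.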